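Ring Size at the Core: From Cyclopentyl to Cyclohexyl

This account rests on a few compounds, and the source may have more. Where it says the series, first, only, none or still open, it means among the compounds named here.

Measured so far:
compound 1 `O=c1cc(-c2ccccc2)oc2ccc(OCCCCCCN3CCCCC3)cc12` with 54 nM
compound 2 `O=c1cc(C2CCCCC2)oc2ccc(OCCCCCCN3CCC(O)CC3)cc12` with 46 nM
compound 3 `O=c1cc(C2CCCC2)oc2ccc(OCCCCCCN3CCCCC3)cc12` with 38 nM

In an assay on isolated protein (Cavia porcellus) with Sigma non-opioid intracellular receptor 1 (Homo sapiens) as the target, read by radioligand binding (on this read-out higher numbers stand for weaker inhibition and lower numbers for stronger inhibition), compound 3 gives the lowest of the three numbers, yet compound 2 and compound 1 both sit within the usual scatter of it, so none of the three can be called stronger or weaker than another. Within the data shown here, the one measured step that changes the same position, a 1.4-fold lower number from compound 1 to compound 3 (0.15 log units; within the scatter), stayed within the scatter as well.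

Compound 4 `O=c1cc(C2CCCCC2)oc2ccc(OCCCCCCN3CCCCC3)cc12` differs from compound 3 in one place: cyclohexyl in place of cyclopentyl on an aromatic carbon. Among the measured compounds shown here, no measured pair changes a cyclopentyl to a cyclohexyl directly. What is known is that swapping phenyl for cyclopentyl barely moved this assay, and that compound 2, which already carries a cyclohexyl, sits close to compound 3. On that basis the expected step of a 1.1-fold higher number from compound 3 to compound 4 (0.02 log units; within the scatter) is small, with no clear direction beyond the scatter. Compound 4 is therefore estimated at 40 nM, with a likely range from 20 nM to 80 nM.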

Compound 4, half-maximal inhibitory concentration: 32 nM
Compound 4: middle estimate off by 1.3-fold (0.10 log units), on the high side, and the stated range covers the measured number.
By their numbers in this assay, from the lowest: compounds 4, 3, 2 and 1 (each within the scatter of the next).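

In this assay the direct step of a 1.2-fold lower number from compound 3 to compound 4 (0.07 log units; within the scatter) lies within the scatter, so cyclopentyl and cyclohexyl on this aromatic carbon cannot be told apart. The step of a 1.7-fold lower number from compound 1 to compound 4 (0.23 log units; within the scatter), which puts cyclohexyl in place of phenyl at the same carbon, also stays within the scatter, as does the step of a 1.4-fold lower number from compound 2 to compound 4 (0.16 log units; within the scatter), where hydrogen replaces hydroxy on a saturated ring carbon, so none of these three changes has a measurable effect here. Nothing available explains why these steps are so small.

As far as these compounds go, it remains open whether a methyl group or a pyridyl ring on this aromatic carbon would move the number beyond the scatter. Also open, from the compounds shown here alone, is whether an amine or a carboxylic acid on the cyclohexyl ring would do so.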